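The source may hold more compounds than are shown below. What is called first, only, known or untested is meant among the compounds shown, and "the series" means these compounds.

Among the measured compounds shown here, compound 2 `Cn1nc2c(=O)n(CC3(O)CCN(Cc4ccc(-c5ccco5)cc4Cl)CC3)cnc2c1-c1ccc(CNCCO)cc1` stands at the low end of the three numbers measured so far. In an assay on isolated protein for inhibition of ubiquitin carboxyl-terminal hydrolase 7 (Homo sapiens), with stated times of 30 min and 2 h (on this read-out lower numbers stand for stronger inhibition and higher numbers for weaker inhibition), compound 2 gives 8.2 nM, whereas compound 1 `Cn1nc2c(=O)n(CC3(O)CCN(Cc4ccc(-c5ccncc5)cc4Cl)CC3)cnc2c1-c1ccc(CN)cc1` gives 257 nM and compound 3 `Cn1nc2c(=O)n(CC3(O)CCN(Cc4ccc(-n5ccnc5)cc4Cl)CC3)cnc2c1-c1ccc(CN)cc1` gives 228 nM. For the measured compounds named here, the only step between two measured compounds that differ in one place is a 1.1-fold lower number from compound 1 to compound 3 (0.05 log units; within the scatter), so that exchange on the aromatic carbon made no difference beyond the scatter. Compound 2 differs from compounds 1 and 3 in two places at once, so its gap to them cannot be assigned to either place alone.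

Compound 4 `CN(C)Cc1ccc(-c2c3ncn(CC4(O)CCN(Cc5ccc(-c6ccco6)cc5Cl)CC4)c(=O)c3nn2C)cc1` carries the change (dimethylamino in place of (2-hydroxyethyl)amino on a saturated chain carbon bound to an aromatic carbon). Going by the values given here, no measured step touches this position: compounds 1 and 3 carry an unsubstituted aminomethyl there, but each also differs from compound 2 elsewhere, so their numbers only show that compound 2 sits well below both. With nothing to bear on the change, he expects compound 4 to stay near compound 2, with a step of a 1.5-fold higher number from compound 2 to compound 4 (0.17 log units; within the scatter) in this assay. His estimate for compound 4 is 12 nM, within a range from 4 nM to 40 nM.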

Compound 4, half-maximal inhibitory concentration: 131 nM
Estimate against measurement, compound 4: 11-fold (1.04 log units) below; the measured number lies above the stated range.
By their numbers in this assay, from the lowest: compound 2; then compounds 4, 3 and 1 (each within the scatter of the next).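

In this assay, among the compounds shown here, the exchange of (2-hydroxyethyl)amino for dimethylamino on a saturated chain carbon bound to an aromatic carbon gives a 16-fold higher number from compound 2 to compound 4 (1.20 log units; beyond the scatter) and is the first single-place step here to lie beyond the scatter. It shows that this position responds strongly to what the amine carries, something compounds 1 and 3 could not show, since each differs from compound 2 in a second place as well, and here the whole gap belongs to this one exchange. The change removes a group with 2 hydrogen-bond donors and 2 hydrogen-bond acceptors and brings in one with 0 donors and 1 acceptor, but no measurement links any of these counts to the loss, which remains unexplained.

The compounds shown leave open whether the hydroxyl oxygen, the amine hydrogen or both matter, a question that (2-methoxyethyl)amino and ethylamino at this position would separate. They also leave open how a longer chain such as (3-hydroxypropyl)amino, or a plain amino group on the same remainder as compound 2, would read out.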